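Swapping an Ethylpyrazole Amide for a Hydroxyphenyl Amide

The source may hold more compounds than are shown below. What is called first, only, known or untested is meant among the compounds shown, and "the series" means these compounds.

Measured compounds:
Compound 1, `CC1(C)C[C@@H](NC(=O)c2cn[nH]c2)c2cc(-c3ccc(Cl)cc3)c(-c3ccc(Cl)cc3Cl)nc2O1`: -3%
Compound 2, `CC1(C)CC(NC(=O)C(C)(C)O)c2cc(-c3ccc(Cl)cc3)c(-c3ccc(Cl)cc3Cl)nc2O1`: -48%
Compound 3, `CCc1cc(C(=O)N[C@@H]2CC(C)(C)Oc3nc(-c4ccc(Cl)cc4Cl)c(-c4ccc(Cl)cc4)cc32)n[nH]1`: -48%

The three compounds share one core and differ only in the group on the amide carbonyl. In a functional assay on the whole organism with Rattus norvegicus as the target, with a stated time of 18 h, at a dose of 3 mg/kg by the oral route (on this read-out higher numbers stand for a weaker effect at the one dose given and lower numbers for a stronger effect), compound 3 gives -48%, the same as compound 2 at the digits shown, and the two together sit at the low end of the three numbers, the end that stands for a stronger effect. Going by the values given here, the only compound clearly apart is compound 1, and the one step that can be traced, a number 45 percentage points lower from compound 1 to compound 3 (beyond the scatter), shows that changing the group on the carbonyl carbon can move this read-out a long way.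

Compound 4, `CC1(C)C[C@@H](NC(=O)c2ccccc2O)c2cc(-c3ccc(Cl)cc3)c(-c3ccc(Cl)cc3Cl)nc2O1`, has not yet been measured. It differs from compound 3 by 2-hydroxyphenyl in place of 5-ethyl-1H-pyrazol-3-yl on a carbonyl carbon. Among the compounds with values here, no measured step describes this particular exchange. Compound 2 and compound 3 show that two quite different groups at this position can give the same number, while compound 1 shows that a third can give a much higher one. On balance the expected step is a number 13 percentage points higher from compound 3 to compound 4 (beyond the scatter), a modest rise. For compound 4 the estimated value in this assay is -35%, expected to fall between -60% and -5%.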

Compound 4, a percentage reported as activity, at one dose (the size of the read-out at that dose, not a potency): -25%
Compound 4: middle estimate off by 10 percentage points, on the low side; low and high end bracket the measured number.
By their numbers in this assay, from the lowest: compounds 2 and 3 (each within the scatter of the next); then compound 4; then compound 1.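

In this assay the 2-hydroxyphenyl group settles at a level of its own on the amide, with a number 23 percentage points higher from compound 3 to compound 4 (beyond the scatter) and with a number 22 percentage points lower from compound 1 to compound 4 (beyond the scatter) on the other side, so this position gives an intermediate result as well as the two extremes seen earlier. The 5-ethyl-1H-pyrazol-3-yl and 2-hydroxyphenyl groups match in heavy atoms, hydrogen-bond donors and hydrogen-bond acceptors, so those counts alone do not fix the read-out here. Nothing available explains why these groups differ in this read-out.

Going by these compounds, how much of the result belongs to the hydroxyl is still open, and a plain phenyl or a 2-methoxyphenyl group on the same carbonyl carbon would help to show that. The part played by the ethyl on the pyrazole is equally unsettled, and a methyl or propyl chain there would test it.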